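Compound 3: 1-acetylpiperidin-4-yl on the shared core

The source may hold more compounds than are shown below. What is called first, only, known or untested is meant among the compounds shown, and "the series" means these compounds.

Compound 1 `Cn1nccc1-c1cnc(NCc2c(F)ccc3c2CCO3)c2cn[nH]c(=O)c12`: 2000 nM
Compound 2 `Cc1nc(CO)ccc1-c1cnc(NCc2c(F)ccc3c2CCO3)c2cn[nH]c(=O)c12`: 3000 nM

Both values come from a physicochemical assay for solubility, read by LC-MS, in phosphate buffer, with a stated time of 24 h, at pH 7.4; a higher number here means a more soluble compound, a lower number a less soluble compound. Going by the values given here, only one comparison exists so far, a 1.5-fold higher number from compound 1 to compound 2 (0.18 log units; within the scatter), so compound 2 cannot be told apart from the only other measured compound. Compound 3 `CC(=O)N1CCC(c2cnc(NCc3c(F)ccc4c3CCO4)c3cn[nH]c(=O)c23)CC1` has not yet been measured. It carries 1-acetylpiperidin-4-yl in place of 6-(hydroxymethyl)-2-methylpyridin-3-yl on an aromatic carbon of the shared core: 1-acetylpiperidin-4-yl in place of 6-(hydroxymethyl)-2-methylpyridin-3-yl on an aromatic carbon. A six-membered aromatic ring thus gives way to a six-membered non-aromatic ring. Among the compounds with values here, the one measured step also exchanged the group at this place, and it stayed within the scatter. However, it joined two aromatic groups, and no measured compound has a non-aromatic ring there, so the data suggest no direction. The expected change is a 1.2-fold higher number from compound 2 to compound 3 (0.07 log units; within the scatter), which means no step beyond the scatter is expected. In this assay the estimate for compound 3 is 3500 nM, with an expected range from 1000 nM to 12000 nM.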

Compound 3, solubility: < 2000 nM
Compound 3 ended at the assay's limit (the forecaster's own chance of this, stated with the estimate: 10%); middle value at least 1.7-fold (0.24 log units) away from the limit.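

Compound 3 puts a six-membered non-aromatic ring at this place for the first time, and in this assay its reading of < 2000 nM is a limit of the assay, not a number: the limit of < 2000 nM in this assay, at which 1 of the 3 values shown sits.

Exchanging the aromatic ring for 1-acetylpiperidin-4-yl gives an at least 1.5-fold lower number from compound 2 to compound 3 (0.17 log units; that floor lies within the scatter), so this non-aromatic ring brought no rise over compound 2, although the floor of this step alone does not separate the two compounds. Exchanging 1-methyl-1H-pyrazol-5-yl for 1-acetylpiperidin-4-yl gives a number no higher from compound 1 to compound 3 (the limit leaves the size open), and this step cannot be read.

The compounds shown leave open how far compound 3 really lies from the other two, and whether the outcome belongs to the non-aromatic ring or to its acetyl group. A piperidin-4-yl with a free amine in place of the acetyl, or with a carboxylic acid on the ring, would help to tell these apart.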